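The source may hold more compounds than are shown below. What is called first, only, known or untested is meant among the compounds shown, and "the series" means these compounds.

In a functional assay on HT-29 cells (Homo sapiens) for cytotoxicity, read by MTT assay, with a stated time of 72 h (on this read-out higher numbers stand for weaker inhibition of growth and lower numbers for stronger inhibition of growth), the three measured compounds give the following numbers.

Compound 1, `C[Se]/C(=N\C(=O)c1cc2ccccc2s1)NC(=O)c1cc2ccccc2s1`, gives 5620 nM.
Compound 2, `CS/C(=N\C(=O)c1sccc1Cl)NC(=O)c1sccc1Cl`, gives 35600 nM.
Compound 3, `CS/C(=N\C(=O)c1cc2ccccc2s1)NC(=O)c1cc2ccccc2s1`, gives 16800 nM.

Compound 2 stands at the highest of the three numbers in this assay, and both others lie beyond the scatter from it. Compounds 2 and 3 share the same arrangement at their centre but carry different outer parts; the difference between the two cores is not broken down here.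

Compounds 3 and 1 differ in one place only: a group of 2 heavy atoms (1 carbon, 1 selenium; no ring) in place of a group of 2 heavy atoms (1 carbon, 1 sulfur; no ring), on a carbon with a double bond to nitrogen. That change gave a 3.0-fold lower number from compound 3 to compound 1 (0.48 log units; beyond the scatter), a step that is beyond the scatter and counts as modest.

Compound 4, `C[Se]/C(=N\C(=O)c1sccc1Cl)NC(=O)c1sccc1Cl`, has not yet been measured in this assay. It is made from compound 2 by the same change: a group of 2 heavy atoms (1 carbon, 1 selenium; no ring) in place of a group of 2 heavy atoms (1 carbon, 1 sulfur; no ring), on a carbon with a double bond to nitrogen. The surroundings of the change are the same in both pairs, so the two changes are the same change on two different cores.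

Within the data shown here, with only one earlier example of this change to go on, it is reasonable to expect that compound 4 shows a step of about the same size as the earlier one, because compound 1 gave a 3.0-fold lower number from compound 3 to compound 1 (0.48 log units; beyond the scatter) against compound 3. On that basis, compound 4 is expected to move from compound 2 by a 3.0-fold lower number from compound 2 to compound 4 (0.47 log units; beyond the scatter), so that compound 4 is estimated at 12000 nM, with a plausible range from 4500 nM to 33000 nM.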

Compound 4, concentration for 50% growth inhibition: 4.9 nM
The estimate for compound 4 lay 2400-fold (3.39 log units) above the measured number, outside the stated range (below it).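

In this assay, putting the group of carbon and selenium in place of methylsulfanyl, on a carbon with a double bond to nitrogen, gave a 7300-fold lower number from compound 2 to compound 4 (3.86 log units; beyond the scatter) and so counts as a large step. Set beside the earlier case, the same change did not carry the same size of step from one core to the other: the same change on two cores in this assay, a 3.0-fold lower number (0.48 log units; beyond the scatter) from compound 3 to compound 1 and a 7300-fold lower number (3.86 log units; beyond the scatter) from compound 2 to compound 4, 2400-fold (3.39 log units) apart, beyond the scatter of two such steps. Among these compounds, this shows that both steps ran in the same direction, towards stronger inhibition of growth, but that the size of the step on one core was a poor guide to its size on the other; with only two pairs, it does not show which feature of the outer parts goes with the large step, or what size of step a third core would give.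

The compounds shown leave open whether the large step belongs to the chlorine on the outer parts of compound 4 or to those outer parts as a whole, which a matched pair carrying a methyl group or a fluorine in place of that chlorine could test. They also leave open whether a longer chain, such as ethyl or propyl, on the selenium would keep the low number of compound 4.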